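Two Stereocentres Inverted: What Compound 4 May Show

This account rests on a few compounds, and the source may have more. Where it says the series, first, only, none or still open, it means among the compounds named here.

In a functional assay on RCC4 cells (Homo sapiens) for antiproliferative activity, read by XTT assay, with a stated time of 48 h (a lower number here means a stronger inhibitor, a higher number a weaker inhibitor), compound 1 (`CC(=O)OC[C@H]1O[C@@H](n2cc(CN(c3ccccc3)S(C)(=O)=O)nn2)[C@H](OC(C)=O)[C@@H]1OC(C)=O`) gives 180000 nM, compound 2 (`CC(=O)OC[C@H]1O[C@@H](n2cc(CN(c3ccc(C#N)cc3)S(C)(=O)=O)nn2)[C@H](OC(C)=O)[C@@H](OC(C)=O)[C@@H]1OC(C)=O`) gives 120000 nM and compound 3 (`CC(=O)OC[C@H]1O[C@@H](n2cc(CN(c3ccc(C#N)cc3)S(C)(=O)=O)nn2)[C@H](OC(C)=O)[C@@H](OC(C)=O)[C@H]1OC(C)=O`) gives 170000 nM. Compound 3 therefore lies within the scatter of both compound 1 and compound 2, and these numbers do not set it apart from either.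

The next compound, compound 4 (`CC(=O)OC[C@H]1O[C@@H](n2cc(CN(c3ccc(C#N)cc3)S(C)(=O)=O)nn2)[C@@H](OC(C)=O)[C@@H](OC(C)=O)[C@@H]1OC(C)=O`), has not yet been measured. Its relation to compound 3 is this: the two compounds have the same atoms and bonds and differ only in configuration as drawn: 2 of 5 stereo elements differ; a stereocentre at a saturated ring carbon is drawn R in compound 3 and S in compound 4; a stereocentre at a saturated ring carbon is drawn S in compound 3 and R in compound 4. No group leaves or enters.

Going by the values given here, one measured step bears on this change: a 1.4-fold higher number from compound 2 to compound 3 (0.15 log units; within the scatter). It is relevant through (the fact that compounds 2 and 3 differ only in the configuration as drawn), and it stays within the scatter. That step alters a single stereocentre, whereas the new one alters two, so it is only a partial guide and leaves open what the second inversion will do. On this evidence, no step beyond the scatter is expected in this assay, and no direction can be favoured. The expected change is a 1.1-fold lower number from compound 3 to compound 4 (0.05 log units; within the scatter), which is a small step. For compound 4 the estimated value is 150000 nM, with an expected range from 70000 nM to 300000 nM.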

Compound 4, half-maximal inhibitory concentration: 240000 nM
Estimate against measurement, compound 4: 1.6-fold (0.20 log units) below; the range from low to high includes it.
By their numbers in this assay, from the lowest: compounds 2, 3, 1 and 4 (each within the scatter of the next).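

In this assay, going by these compounds alone, inverting two saturated ring stereocentres at once gives a 1.4-fold higher number from compound 3 to compound 4 (0.15 log units; within the scatter), so the double inversion, which the earlier compounds did not cover, stays as close as the single inversion did. The pair linked by a single inversion, a 2.0-fold higher number from compound 2 to compound 4 (0.30 log units; within the scatter), also lies within the scatter, and the stereocentre involved is a different one from the stereocentre that separates compound 2 and compound 3. Two separate stereocentres have now each been inverted singly, and none of the three isomers is set apart from the others by these numbers, which shows that in this assay the change of configuration alone has left no step beyond the scatter: the fact that compounds 2 and 4 differ only in the configuration as drawn.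

Compound 1 lacks the nitrile and also differs in the core, so the part played by the nitrile alone cannot be read from it. On these data alone, whether free hydroxyl groups in place of the acetyl esters, or an amine or a carboxylic acid in place of the nitrile, would produce a step beyond the scatter in this assay remains open.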